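Compound 4: a 2-Fluorophenyl Analogue and Its Expected Potency

The source may report more compounds than this note shows. Statements on the series, on what has been measured and on what is new or still open speak of the compounds shown alone.

Of the compounds shown here, three sharing one core have been measured in a functional assay on HL-60 cells (Homo sapiens) for inhibition, read by MTT assay, with a stated time of 72 h; a higher number here means a weaker inhibitor, a lower number a stronger inhibitor. Compound 1 `Cc1nc(-c2ccccc2)c(C(=O)N2CCN(c3c(C)cccc3C)CC2)o1` gives 146 nM, compound 2 `Cc1nc(-c2ccccc2)c(C(=O)N2CCN(c3ccccc3Cl)CC2)o1` gives 124 nM, and compound 3 `Cc1ccc(N2CCN(C(=O)c3oc(C)nc3-c3ccccc3)CC2)c(C)c1` gives 101 nM. The three numbers lie within the scatter of one another, so compound 3 cannot be called more potent than compound 1 or compound 2: the steps of a 1.4-fold lower number from compound 1 to compound 3 (0.16 log units; within the scatter) and a 1.2-fold lower number from compound 2 to compound 3 (0.09 log units; within the scatter) are both within the scatter, as is the step of a 1.2-fold lower number from compound 1 to compound 2 (0.07 log units; within the scatter).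

Compound 4 `Cc1nc(-c2ccccc2)c(C(=O)N2CCN(c3ccccc3F)CC2)o1` has not yet been measured in this assay. Relative to compound 3 the change is 2-fluorophenyl in place of 2,4-dimethylphenyl on an amine nitrogen in a ring. All three measured steps bear on it, since each of them also exchanges the aryl group on the amine nitrogen in the ring, and none of them moved the number beyond the scatter. On that basis, no step beyond the scatter is expected in this assay for compound 4 in either direction. The expected step of a 1.1-fold higher number from compound 3 to compound 4 (0.06 log units; within the scatter) is accordingly one that stays within the scatter. Compound 4 is therefore estimated to give 115 nM in this assay, with an expected range from 55 nM to 240 nM.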

Compound 4, half-maximal inhibitory concentration: 147 nM
Compound 4: the middle estimate sits 1.3-fold (0.11 log units) below what was measured; measured number inside the range.
By their numbers in this assay, from the lowest: compounds 3, 2, 1 and 4 (each within the scatter of the next).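

In this assay, going by these compounds alone, fluoro in place of chloro on an aromatic carbon, an exchange of one halogen for another that the earlier compounds did not offer, gives a 1.2-fold higher number from compound 2 to compound 4 (0.07 log units; within the scatter), so this exchange on the aryl group leaves the number within the scatter. The 2-fluorophenyl group, with 7 heavy atoms against the 8 of the 2,4-dimethylphenyl group and with no methyl on its ring, also stays within the scatter of both dimethylphenyl compounds, with a 1.5-fold higher number from compound 3 to compound 4 (0.16 log units; within the scatter) and a 1.0-fold higher number from compound 1 to compound 4 (0.00 log units; within the scatter), so across these four compounds no exchange of the aryl group on the amine nitrogen in the ring moves the number beyond the scatter, and none of the four goes against this. Nothing available explains why these aryl groups give such similar numbers.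

The compounds shown leave open whether a methoxy group, an amine or a carboxylic acid on that aryl ring, or a longer chain in place of the ring, would also stay within the scatter. They also leave open how the number responds to changes elsewhere on the shared core, which is the same in all four compounds.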